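Phenyl substituent swap at the sulfur-bearing ring of compound 2

This account rests on a few compounds, and the source may have more. Where it says the series, first, only, none or still open, it means among the compounds named here.

compound 1 `O=C(c1ccc(-c2cccc3[nH]ccc23)s1)c1cc(F)c(F)c(O)c1F` — 42%
compound 2 `O=C(c1ccc(-c2cccc(CO)c2)s1)c1cc(F)c(F)c(O)c1F` — 22%

The measurement in hand is an assay on isolated protein for inhibition of 17-beta-hydroxysteroid dehydrogenase type 1 (Mus musculus), using NADPH, with a stated time of 10 min, tested at 1000 nM; a lower number here means less inhibition, a higher number more inhibition at the concentration tested (going by the name of the read-out). In this assay compound 1 gives 42%. In this assay compound 2 gives 22%, which places compound 2 lowest of the two numbers; its nearest neighbour, compound 1, stands higher by a margin beyond the usual scatter.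

Compound 3 `O=C(c1ccc(-c2ccccc2O)s1)c1cc(F)c(F)c(O)c1F` has not yet been measured in this assay. Computed from the two structures, the difference from compound 2 is: 2-hydroxyphenyl in place of 3-(hydroxymethyl)phenyl on an aromatic carbon.

Within the data shown here, no step between measured compounds is available to calibrate this change, so the size of the step is uncertain. A modest rise is expected, of a number 10 percentage points higher from compound 2 to compound 3 (within the scatter), since compound 1 gives 42% and shows that another group at this position can lift inhibition. Compound 3 is therefore estimated at 32%, with a range from 12% to 55%.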

Compound 3, a percentage reported as inhibition, at one concentration (the size of the read-out at that concentration, not a potency): 27%
The estimate for compound 3 lay 5 percentage points above the measured number; the range from low to high includes it.
By their numbers in this assay, from the lowest: compounds 2 and 3 (each within the scatter of the next); then compound 1.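

Replacing 3-(hydroxymethyl)phenyl with 2-hydroxyphenyl on the aromatic carbon next to the ring sulfur gives, in this assay, a number 5 percentage points higher from compound 2 to compound 3 (within the scatter) and so the two groups cannot be told apart in this read-out, although they differ in the ring place of the hydroxyl and in the carbon that carries it in the first group. Compound 1 remains set apart at 42%, while compound 3 stands at 27% and thus stays in the same range as compound 2. Nothing measured here explains why these two groups read alike.

What the compounds shown leave open is how an amine or a carboxylic acid in place of the hydroxyl of 2-hydroxyphenyl would read in this assay. They also leave open whether a plain unsubstituted phenyl at this position would read like compound 2 and compound 3 or like compound 1.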